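From a Heptyl Amide to a Benzyl Urea

The source may report more compounds than this note shows. Statements on the series, on what has been measured and on what is new or still open speak of the compounds shown alone.

Two measured compounds share one core and differ at both of its ends. Compound 1 `N#Cc1ccc(C(=O)Nc2ccc3nc(NC(=O)C4CCCCC4)sc3c2)cc1` gives 3.3 ug/mL in a functional assay on WI-38 VA13 cells (Homo sapiens) for cytotoxicity; on this read-out higher numbers stand for an effect only at larger amounts of compound and lower numbers for an effect already at smaller amounts. Compound 2 `CCCCCCCC(=O)Nc1nc2ccc(NC(=O)c3c(Cl)cccc3Cl)cc2s1` gives 0.18 ug/mL in this assay, the lower of the two numbers, and its gap to compound 1 lies beyond the usual scatter of repeated measurements. Since compound 1 and compound 2 differ in more than one place, the numbers alone do not tell which part of the molecule carries that gap.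

Compound 3 `O=C(NCc1ccccc1)Nc1nc2ccc(NC(=O)c3c(Cl)cccc3Cl)cc2s1` keeps everything of compound 2 except one group: benzylamino in place of heptyl on a carbonyl carbon. The heptyl chain leaves and a benzylamino group enters on the carbonyl carbon, so that a heptylcarbonyl becomes a benzylcarbamoyl. Among the measured compounds shown here, no measured pair shows this exchange on its own, so any expectation rests on compound 2 alone and carries wide uncertainty. The step expected in this assay is a 3.3-fold higher number from compound 2 to compound 3 (0.52 log units; beyond the scatter), a modest rise rather than none. Compound 3 is accordingly estimated at 0.6 ug/mL, within a range from 0.15 ug/mL to 3 ug/mL.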

Compound 3, half-maximal effective concentration: 0.15 ug/mL
The estimate for compound 3 lay 4.0-fold (0.60 log units) above the measured number; low and high end bracket the measured number.
By their numbers in this assay, from the lowest: compounds 3 and 2 (each within the scatter of the next); then compound 1.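

Placing benzylamino in place of heptyl on a carbonyl carbon gives a 1.2-fold lower number from compound 2 to compound 3 (0.08 log units; within the scatter) in this assay, the first comparison here in which only this end of the molecule differs. A chain without a ring and a group with a six-membered aromatic ring and a hydrogen-bond donor therefore give numbers that cannot be told apart in this read-out, so at this position the assay does not distinguish these two quite different groups. Nothing in the data explains this closeness.

A carboxylic acid, an amine or a shorter chain such as butyl on the same carbonyl carbon remains untested in the compounds shown, so it is open whether the tolerance seen with heptyl and benzylamino extends to such groups. Also open, as far as these compounds go, is which end of the molecule carries the gap to compound 1, since compound 1 still differs from both compound 2 and compound 3 in more than one place, and only a compound changed at a single end could separate the two contributions.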